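Aryl ether variation and tolerated concentration in the series

The source may report more compounds than this note shows. Statements on the series, on what has been measured and on what is new or still open speak of the compounds shown alone.

Compound 1 `COc1cccc(OC(c2ccc(C(F)(F)F)cc2)C2CCN(C(C)CCNC(=O)c3c(Cl)cncc3Cl)CC2)n1` gives 32700 nM in an ADME assay on PBMC cells (Homo sapiens) for cytotoxicity (a higher number here means that more compound is tolerated, a lower number that less compound is tolerated), the lowest of the two numbers available. Compound 2 `CC(CCNC(=O)c1c(Cl)cncc1Cl)N1CCC(C(=O)c2ccc(Br)cc2)CC1` gives 189000 nM in this assay, a value beyond the scatter from compound 1. Compound 3 `CC(CCNC(=O)c1c(Cl)cncc1Cl)N1CCC(C(Oc2cccc(Cl)n2)c2ccc(S(C)(=O)=O)cc2)CC1` reaches only a limit in this assay, reported as > 29500 nM; this is the limit of > 29500 nM in this assay, at which 1 of the 3 values shown sits. Compound 4 `COC(=O)c1cccc(OC(c2ccc(C(F)(F)F)cc2)C2CCN(C(C)CCNC(=O)c3c(Cl)cncc3Cl)CC2)c1` is not yet measured and differs from compound 1 by 3-(methoxycarbonyl)phenyl in place of 6-methoxypyridin-2-yl on an oxygen on a saturated carbon. No measured step among the compounds shown covers a change of this kind, so there is no direct guide. For compound 4 the expected step of a 1.1-fold lower number from compound 1 to compound 4 (0.04 log units; within the scatter) is small, within the scatter, in no particular direction. The estimate for compound 4 in this assay is 30000 nM, with a range from 12000 nM to 80000 nM.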

Compound 4, half-maximal cytotoxic concentration: 15200 nM
Compound 4: the middle estimate sits 2.0-fold (0.30 log units) above what was measured; the range from low to high includes it.
By their numbers in this assay, from the lowest: compound 4; then compound 1; then compound 2.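

In this assay, among the compounds shown here, the group on the ether oxygen is not neutral: the change gives a 2.2-fold lower number from compound 1 to compound 4 (0.33 log units; beyond the scatter) and so counts as a modest step, the first single-place step. Both groups carry the same counts of hydrogen-bond donors and acceptors, so these counts alone do not fix the tolerated concentration here. No measurement at hand bears on this step.

The change swaps the ring nitrogen and the substituent together, leaving their separate contributions unresolved. Going by these compounds, a carboxylic acid or an amine in place of the methyl ester remains open.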